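The source may hold more compounds than are shown below. What is called first, only, known or untested is meant among the compounds shown, and "the series" means these compounds.

In an ADME assay on microsomes from liver (Rattus norvegicus) for metabolic stability (on this read-out lower numbers stand for a shorter-lived compound and higher numbers for a longer-lived compound), compound 2 `Cn1nc2c(=O)n(CC3(O)CCN(Cc4ccc(-c5cccs5)cc4Cl)CC3)cnc2c1-c1ccc(CN)cc1` gives 1.38 h, the higher of the two measured numbers, while compound 1 `Cn1nc2c(=O)n(CC3(O)CCN(Cc4ccc(-c5ccco5)cc4Cl)CC3)cnc2c1-c1ccc(CNS(C)(=O)=O)cc1` gives 0.433 h, a gap beyond the scatter. Compound 3 `Cn1nc2c(=O)n(CC3(O)CCN(Cc4ccc(-c5ccco5)cc4Cl)CC3)cnc2c1-c1ccc(CN)cc1` differs from compound 2 in one place, with furan-2-yl in place of thiophen-2-yl on an aromatic carbon. Among the measured compounds shown here, no measured pair isolates this exchange, since compound 1 bears furan-2-yl but also differs elsewhere. The expected step is a 1.4-fold lower number from compound 2 to compound 3 (0.14 log units; within the scatter), a small fall within the scatter. The estimate for compound 3 is 1 h, with an expected range from 0.5 h to 2 h.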

Compound 3, half-life: 2.37 h
The estimate for compound 3 lay 2.4-fold (0.37 log units) below the measured number; the whole stated range lies below it.
By their numbers in this assay, from the lowest: compound 1; then compounds 2 and 3 (each within the scatter of the next).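

Putting furan-2-yl in place of thiophen-2-yl gives (a 1.7-fold higher number from compound 2 to compound 3 (0.23 log units; within the scatter)) in this assay, so the two five-membered rings are not told apart on this read-out. Hydrogen in place of methylsulfonyl on the amine nitrogen gives (a 5.5-fold higher number from compound 1 to compound 3 (0.74 log units; beyond the scatter)), and this single-place step shows that the amine nitrogen can carry a change beyond the scatter. Nothing available accounts for either step. The compounds shown leave open how a phenyl or thiazol-2-yl ring would read at the five-membered ring's place. They also leave open how an acetyl group on the amine nitrogen would read.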